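Amide-nitrogen substituents on the shared core in melanoma growth inhibition

The source may hold more compounds than are shown below. What is called first, only, known or untested is meant among the compounds shown, and "the series" means these compounds.

Measured compounds:
compound 1, `CN1CCN(C(=O)c2c(NC(=O)NS(=O)(=O)c3ccccc3)sc3c2CCCCC3)CC1`: 61200 nM
compound 2, `CCCCNC(=O)c1c(NC(=O)NS(=O)(=O)c2ccccc2)sc2c1CCCCC2`: 76700 nM

Both carry the same core and the same sulfonylurea side; they differ only in the group on the carbonyl carbon. In a functional assay on cells (Melanoma cell, Homo sapiens) for inhibition, with a stated time of 48 h (a higher number here means a weaker inhibitor of growth, a lower number a stronger inhibitor of growth), compound 1 gives 61200 nM and compound 2 gives 76700 nM. Going by the values given here, the single measured step, a 1.3-fold higher number from compound 1 to compound 2 (0.10 log units; within the scatter), lies within the scatter, so on the numbers at hand compound 2 stands with the higher number of the two but is not separable from compound 1.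

Compound 3, `O=C(Nc1sc2c(c1C(=O)NNc1ccc(Cl)cc1)CCCCC2)NS(=O)(=O)c1ccccc1`, is not yet measured. It follows from compound 2 by (4-chlorophenyl)amino in place of butyl on an amide-type nitrogen. Among the compounds with values here, the only step that bears on this position, a 1.3-fold higher number from compound 1 to compound 2 (0.10 log units; within the scatter), shows that exchanging the amide substituent between the two measured groups left this assay essentially unchanged. That is one step only, and the group entering in compound 3 is unlike either of the measured ones, so the expectation rests on thin ground. No movement beyond the scatter is expected; the estimated step of a 1.2-fold lower number from compound 2 to compound 3 (0.07 log units; within the scatter) is small. Compound 3 is expected at 65000 nM in this assay, with a range of 25000 nM to 170000 nM.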

Compound 3, concentration for 50% growth inhibition: 4200 nM
Beside the measured number, compound 3's estimate is 15-fold (1.19 log units) above it; measured number below the stated range.
By their numbers in this assay, from the lowest: compound 3; then compounds 1 and 2 (each within the scatter of the next).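

The position on the amide-type nitrogen is not indifferent in this assay: (4-chlorophenyl)amino in place of butyl gives an 18-fold lower number from compound 2 to compound 3 (1.26 log units; beyond the scatter) and, on the carbonyl carbon, ((4-chlorophenyl)amino)amino in place of 4-methylpiperazin-1-yl gives a 15-fold lower number from compound 1 to compound 3 (1.16 log units; beyond the scatter), so the flat result between the two earlier groups does not extend to every group at this position. Both steps are beyond the scatter and arrive at compound 3 from two quite different groups, while compounds 1 and 2 remain within the scatter of each other. The data give no measured basis for explaining this difference.

The change brings in a nitrogen, a six-membered aromatic ring and a chlorine together, so the compounds shown do not separate the contribution of each: a plain phenylamino group would isolate the chlorine, and a 4-chlorophenyl or 4-chlorobenzyl group on the amide nitrogen would isolate the added nitrogen. Also open, going by these compounds, is whether the chlorine's place matters, as a 3-chlorophenylamino group would show, and whether another substituent such as methoxy or a fluorine can stand in for it.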